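A few compounds are considered here, and "the series" means these few. Any claim that something is new, unique, unknown or untested is made for them only; others in the source may bear on it.

Measured compounds: compound 1 `Cn1ncc(Cl)c1-c1cc(C(=O)N[C@@H]2CN[C@H](CCN3CCC(O)CC3)C[C@H]2c2ccc(Cl)c(Cl)c2)oc1Cl` at 13700 nM; compound 2 `COCC[C@@H]1C[C@@H](c2ccc(Cl)c(Cl)c2)[C@H](NC(=O)c2cc(-c3c(Cl)cnn3C)c(Cl)o2)CN1` at 470 nM; compound 3 `CNC(=O)C[C@@H]1C[C@@H](c2ccc(Cl)c(Cl)c2)[C@H](NC(=O)c2cc(-c3c(Cl)cnn3C)c(Cl)o2)CN1` at 450 nM.

In a functional assay on HCT-116 cells (Homo sapiens) for antiproliferative activity, read by sulforhodamine B assay, with a stated time of 72 h (on this read-out higher numbers stand for weaker inhibition and lower numbers for stronger inhibition), compound 3 gives 450 nM, the lowest of the three numbers, though it sits within the scatter of compound 2, so the two cannot be ordered. Compound 1 lies far from both: a 30-fold lower number from compound 1 to compound 3 (1.48 log units; beyond the scatter) and a 29-fold lower number from compound 1 to compound 2 (1.46 log units; beyond the scatter) show that exchanging the 4-hydroxypiperidin-1-yl-bearing side chain for either methoxymethyl or methylcarbamoyl is a large step.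

Compound 4 `CCC[C@@H]1C[C@@H](c2ccc(Cl)c(Cl)c2)[C@H](NC(=O)c2cc(-c3c(Cl)cnn3C)c(Cl)o2)CN1` has not been measured in this assay. Its difference from compound 3 is ethyl in place of methylcarbamoyl on a saturated chain carbon bound to a saturated ring carbon. The step that bears most directly on it is a 1.0-fold lower number from compound 2 to compound 3 (0.02 log units; within the scatter), which showed that swapping one short chain group for another at this position left the number essentially unchanged. Among the compounds with values here, no measured step, however, removes the hydrogen-bond donor and acceptor from the chain altogether; the only large steps seen involve the much bigger change away from compound 1. The account therefore expects no step beyond the scatter, with at most a slight rise in the number: a 1.4-fold higher number from compound 3 to compound 4 (0.16 log units; within the scatter). Compound 4 is estimated at 650 nM, in a range from 250 nM to 1700 nM.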

Compound 4, half-maximal inhibitory concentration: 1020 nM
The estimate for compound 4 lay 1.6-fold (0.20 log units) below the measured number; measured number inside the range.
By their numbers in this assay, from the lowest: compounds 3 and 2 (each within the scatter of the next); then compound 4; then compound 1.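

In this assay the propyl chain of compound 4 can be told apart from the two chains that carry oxygen or nitrogen: a 2.3-fold higher number from compound 3 to compound 4 (0.36 log units; beyond the scatter) and a 2.2-fold higher number from compound 2 to compound 4 (0.34 log units; beyond the scatter) are both modest, whereas compounds 2 and 3 could not be ordered. The earlier compounds shown here showed only that methoxymethyl and methylcarbamoyl give the same result within the scatter; the new value shows that the end of the chain, on a saturated chain carbon bound to a saturated ring carbon, does still matter when ethyl enters in their place. Even so, a 13-fold lower number from compound 1 to compound 4 (1.13 log units; beyond the scatter) is a large step, so compound 4 stays much closer to compounds 2 and 3 than to compound 1, and the loss on going to the plain chain is small beside the gap that separates the 4-hydroxypiperidin-1-yl chain from all the others. Nothing available explains these differences.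

The compounds shown leave open whether an amine or a carboxylic acid at the end of a short chain would fall with compounds 2 and 3 or with compound 4. They also leave open whether a longer alkyl chain would raise the number further, and whether the large step from compound 1 belongs to its piperidine ring or to the length of its chain.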